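Shifting the aryl pattern in a tricyclic antiproliferative series

The source may hold more compounds than are shown below. What is called first, only, known or untested is meant among the compounds shown, and "the series" means these compounds.

Measured compounds:
compound 1 `CCC1=C(O)c2c(oc(-c3ccc(CC)cc3)cc2=O)C(CC)(CC)C1=O`: 0.07 uM
compound 2 `CCC1=C(O)c2c(oc(-c3ccc(O)cc3)cc2=O)C(CC)(CC)C1=O`: 20.6 uM
compound 3 `CCC1=C(O)c2c(oc(-c3ccc(C)c(F)c3)cc2=O)C(CC)(CC)C1=O`: 2.95 uM

In a functional assay on KBVIN cells (Homo sapiens) for antiproliferative activity, read by sulforhodamine B assay, with a stated time of 3 days (on this read-out lower numbers stand for an effect already at smaller amounts and higher numbers for an effect only at larger amounts of compound), compound 1 gives the lowest number of the three, with compound 3 nearest and compound 2 furthest. Compound 4 `CCC1=C(O)c2c(oc(-c3cc(C)c(C)cc3C)cc2=O)C(CC)(CC)C1=O` carries 2,4,5-trimethylphenyl in place of 4-ethylphenyl on an aromatic carbon. Among the compounds with values here, two measured steps bear on this change: a 290-fold higher number from compound 1 to compound 2 (2.47 log units; beyond the scatter) and a 42-fold higher number from compound 1 to compound 3 (1.62 log units; beyond the scatter). Both replacements of the 4-ethylphenyl moved the number upward by a large amount, and the step to compound 3, which also alters the pattern of substituents on that ring, is the closer comparison. A higher number is therefore expected for compound 4, though not beyond what compound 3 showed. For compound 4 the estimate is 1 uM, spanning 0.15 uM to 8 uM, which corresponds to an expected 14-fold higher number from compound 1 to compound 4 (1.15 log units; beyond the scatter).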

Compound 4, concentration for half-maximal effect: 4.37 uM
The estimate for compound 4 lay 4.4-fold (0.64 log units) below the measured number; the measured number falls inside the stated range.
By their numbers in this assay, from the lowest: compound 1; then compounds 3 and 4 (each within the scatter of the next); then compound 2.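

In this assay, the all-carbon 2,4,5-trimethylphenyl group does not recover what the 4-ethylphenyl group gives (a 62-fold higher number from compound 1 to compound 4 (1.80 log units; beyond the scatter)). Set against the 3-fluoro-4-methylphenyl group, it cannot be told apart (a 1.5-fold higher number from compound 3 to compound 4 (0.17 log units; within the scatter)), while it still improves on the 4-hydroxyphenyl group (a 4.7-fold lower number from compound 2 to compound 4 (0.67 log units; beyond the scatter)), so a ring carrying only carbon substituents is not enough on its own to match compound 1. Nothing given here explains these differences. Open, on these data alone, is whether a propyl chain in place of the ethyl of compound 1, or an amine on that ring, would keep the low number.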